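Moving the fluorine on the phenyl ring of compound 2

The compounds below may be only part of what the source reports. "The series", "measured", "known", "first", "only" and "open" are said of these compounds alone.

Of the compounds shown here, two built on one shared core have been measured in an ADME assay on the whole organism (strain Sprague-Dawley) for pharmacokinetics, with Rattus norvegicus as the target, read by LC-MS; on this read-out lower numbers stand for lower oral bioavailability and higher numbers for higher oral bioavailability. Compound 1, `O=C(COc1nn(-c2ccccc2F)c2ccc(F)cc12)N1CCOCC1`, gives 22%. Compound 2, `O=C1NCCN1CCOc1nn(-c2ccccc2F)c2ccc(F)cc12`, gives 17%. For the measured compounds named here, the only step measured so far, a number 5 percentage points lower from compound 1 to compound 2 (within the scatter), concerns a change on the saturated chain carbon bound to an oxygen on the aromatic ring. On the numbers shown, compound 2 has the lower of the two values, but the gap to compound 1 lies within the scatter, so the two cannot be told apart.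

Compound 3, `O=C1NCCN1CCOc1nn(-c2ccc(F)cc2)c2ccc(F)cc12`, differs from compound 2 in another place: 4-fluorophenyl in place of 2-fluorophenyl on an aromatic nitrogen. Going by the values given here, no measured step touches the fluorophenyl group on the aromatic nitrogen, so nothing measured bears directly on this change; the one step available was within the scatter and concerned a different part of the molecule. With the same atoms joined differently and no guidance from the data, no step beyond the scatter is expected in this assay. Compound 3 is therefore expected to show 17%, within an estimated range of 7% to 32%. The step expected is no change at the digits printed from compound 2 to compound 3 (within the scatter).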

Compound 3, oral bioavailability: 54%
Compound 3: the middle estimate sits 37 percentage points below what was measured, and the stated range ends below it.
By their numbers in this assay, from the lowest: compounds 2 and 1 (each within the scatter of the next); then compound 3.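

In this assay, where the fluorine sits on the phenyl ring matters a great deal: with the same atoms joined differently, 4-fluorophenyl in place of 2-fluorophenyl on the aromatic nitrogen gives a number 37 percentage points higher from compound 2 to compound 3 (beyond the scatter). The earlier step, made on the saturated chain carbon bound to an oxygen, stayed within the scatter, so this is the first clear difference among these compounds, and it appears at the group on the aromatic nitrogen. The data offer no explanation of why this change has so large an effect on oral bioavailability.

Going by these compounds, it remains open whether the higher number comes from having 4-fluorophenyl on that nitrogen or simply from no longer having 2-fluorophenyl there, a question that a plain phenyl, 3-fluorophenyl or 4-chlorophenyl group at the same place could help to settle. For the compounds shown here, it is also open whether 4-fluorophenyl would give a similar step when combined with the (morpholin-4-yl)carbonyl group of compound 1, which would show whether the effect holds beyond the single pair of compounds seen here.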